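The source may hold more compounds than are shown below. What is called first, only, known or untested is meant among the compounds shown, and "the series" means these compounds.

Working notes on the series. Within the data shown here, the shared core of compound 1 `COc1ccc(S(=O)(=O)N2CCc3cccc(-c4ccco4)c32)cc1` carries a furan-2-yl on an aromatic carbon of the fused ring system, and in a functional assay on MKN-45 cells (Homo sapiens) for inhibition, with a stated time of 72 h (a lower number here means a stronger inhibitor, a higher number a weaker inhibitor), compound 1 gives 42 nM, the second highest of the three numbers so far. Compound 2 `COc1ccc(S(=O)(=O)N2CCc3cccc(-c4ccc([N+](=O)[O-])cc4)c32)cc1` gives 34 nM in this assay, and the move a 1.2-fold lower number from compound 1 to compound 2 (0.09 log units; within the scatter) shows that swapping the five-membered aromatic ring for a 4-nitrophenyl leaves the number essentially where it was. Compound 3 `COc1ccc(S(=O)(=O)N2CCc3cccc(-c4ccc(N(C)C)cc4)c32)cc1` gives 237 nM, and the move a 5.6-fold higher number from compound 1 to compound 3 (0.75 log units; beyond the scatter) is the one clear shift in the set; the pair a 7.0-fold higher number from compound 2 to compound 3 (0.84 log units; beyond the scatter) places the two six-membered aromatic rings on either side of compound 1.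

Compound 4 `COc1ccc(S(=O)(=O)N2CCc3cccc(-c4ccccc4)c32)cc1` is the next step from compound 1: phenyl in place of furan-2-yl on an aromatic carbon. The step from compound 1 to compound 2 is the one that bears most directly on it, since it also puts a six-membered aromatic ring of carbon in place of the furan-2-yl, and it stayed within the scatter. The step to compound 3 warns that a six-membered ring can carry a modest loss, but the group that drove it is absent here. Compound 4 is therefore expected to sit close to compound 1, with a step of a 1.3-fold higher number from compound 1 to compound 4 (0.12 log units; within the scatter) that is not expected to exceed the scatter, and its estimated value is 55 nM with a range from 22 nM to 140 nM.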

Compound 4, half-maximal inhibitory concentration: 117 nM
Compound 4: middle estimate off by 2.1-fold (0.33 log units), on the low side, within the range that was stated.
By their numbers in this assay, from the lowest: compounds 2 and 1 (each within the scatter of the next); then compound 4; then compound 3.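

The step of a 2.8-fold higher number from compound 1 to compound 4 (0.44 log units; beyond the scatter) in this assay shows that a six-membered aromatic ring of carbon only does not by itself match furan-2-yl at this position, so the closeness of compound 2 to compound 1 does not carry over to the plain phenyl. Compound 4 also serves as a reference for what is attached to that phenyl, and the two groups move the number in opposite directions: the step of a 3.4-fold higher number from compound 2 to compound 4 (0.54 log units; beyond the scatter) shows a rise when hydrogen replaces nitro, while the step of a 2.0-fold lower number from compound 3 to compound 4 (0.31 log units; beyond the scatter) shows a fall when hydrogen replaces dimethylamino. No measurement in hand accounts for either direction or for the gap between phenyl and furan-2-yl.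

The compounds shown leave open whether another group in the place of the nitro, such as a nitrile or a carboxylic acid, would also bring the number down from that of compound 4, and whether a primary amine would raise it as dimethylamino does. They also leave open whether thiophen-2-yl or another five-membered aromatic ring would hold the number of compound 1.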